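Shortening the amino side chain of a biphenyl amide agonist

The source may report more compounds than this note shows. Statements on the series, on what has been measured and on what is new or still open speak of the compounds shown alone.

Three compounds have numbers in a functional assay for agonist activity at G protein-coupled receptor 88 (Homo sapiens), read by HTRF and cAMP accumulation; a lower number here means that less compound is needed, a higher number that more compound is needed for the effect. Compound 1 `CC(C)C[C@H](N)CN(C(=O)C(C)Cc1ccccc1)c1ccc(-c2ccccc2)cc1` gives 1.2 nM. Compound 3 `CC[C@@H](C)[C@H](N)CN(C(=O)[C@@H]1C[C@H]1c1ccccc1)c1ccc(-c2ccccc2)cc1` gives 1.4 nM, the higher of the two numbers, though its gap to compound 1 lies within the scatter, so no order between them can be read. Compound 2 `CC(C)CCCN(C(=O)[C@@H]1C[C@H]1c1ccccc1)c1ccc(-c2ccccc2)cc1` is reported only as a limit of the assay, > 100 nM, and not as a number (the limit of > 100 nM in this assay, at which 1 of the 3 values shown sits).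

Among the measured compounds shown here, the one measured step that changes the side chain, an at least 71-fold lower number from compound 2 to compound 3 (1.85 log units; beyond the scatter), shows that bringing in the amino-bearing branch carries the activity into the low range. Compound 4 `CC(C)(N)CN(C(=O)[C@@H]1C[C@H]1c1ccccc1)c1ccc(-c2ccccc2)cc1` keeps that amino group but trims the branch: 1-amino-1-methylethyl in place of 1-amino-2-methylbutyl on a saturated chain carbon bound to an amide-type nitrogen. For the measured compounds named here, no measured step isolates the size of the carbon part of this chain while the amine stays in place; compound 1 and compound 3 carry different chains and also different amide parts, and their values simply sit close together.

Since the amine, which the step from compound 2 to compound 3 singles out, is retained, compound 4 is expected to stay active, with a step of a 3.6-fold higher number from compound 3 to compound 4 (0.55 log units; beyond the scatter) towards a somewhat higher number. Compound 4 is therefore estimated at 5 nM, in the range 1.5 nM to 20 nM.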

Compound 4, half-maximal effective concentration: 1.4 nM
For compound 4 the middle estimate is 3.6-fold (0.55 log units) above the measured one; measured number outside the range, below it.
By their numbers in this assay, from the lowest: compounds 1, 3 and 4 (each within the scatter of the next). At a limit, above all of these: compound 2.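

In this assay, the change to the smaller chain (with the amide part held the same) gives no change at the digits printed from compound 3 to compound 4 (within the scatter). This shows that the extra carbons and the two defined stereocentres of 1-amino-2-methylbutyl are not required on this saturated chain carbon bound to an amide-type nitrogen, where the compact, branched 1-amino-1-methylethyl group does equally well. The large difference from the amine-free isopentyl chain also holds for this shorter group (an at least 71-fold lower number from compound 2 to compound 4 (1.85 log units; beyond the scatter)), so it no longer rests on a single amino-bearing chain, although the size of that step has only a floor, as compound 2 is reported as a limit and not as a number: the limit of > 100 nM in this assay, at which 1 of the 4 values shown sits.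

Going by these compounds, it remains open whether a still smaller aminomethyl group, or a 1-aminocyclopropyl group that ties the two methyl carbons into a ring, would hold the number at this place, and whether a hydroxyl group could stand in for the amine. Also open, on these data alone, is whether 1-amino-1-methylethyl would do as well alongside the amide part of compound 1 as it does alongside that of compound 3.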